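This account rests on a few compounds, and the source may have more. Where it says the series, first, only, none or still open, it means among the compounds named here.

Three compounds share one core. Compound 1 `COc1cc(-n2ncnc2-c2cccc([N+](=O)[O-])c2)cc(OC)c1OC` was tested in a functional assay on Jurkat cells (Homo sapiens) for antiproliferative activity, read by MTT assay, with a stated time of 72 h (a higher number here means a weaker inhibitor, a lower number a stronger inhibitor), and reached only a limit there, > 10000 nM. Compound 2 `COc1cc(-n2ncnc2-c2ccc(F)cc2)cc(OC)c1OC` likewise reached only a limit in this assay, > 10000 nM. Compound 3 `COc1cc(-c2ncnn2-c2ccc(F)cc2)cc(OC)c1OC` also reached only a limit in this assay, > 10000 nM. Compound 1 therefore stands nowhere apart from its companions: all three sit at the limit of > 10000 nM in this assay, at which 3 of the 3 values shown sit, and no ordering among them can be drawn. Compound 4 `COc1cc(-n2ncnc2-c2ccccc2)cc(OC)c1OC` differs from compound 1 in one place: hydrogen in place of nitro on an aromatic carbon. Within the data shown here, no step between measured compounds is available, so any expectation for compound 4 in this assay rests only on the three measured compounds all sitting at the limit. Compound 4 is expected to stay weak, with the step that the limit leaves unreadable from compound 1 to compound 4 expected to amount to nothing beyond the scatter, and with a fair chance that this assay again reports only a limit. Compound 4 is accordingly estimated at 15000 nM, within a range of 4000 nM to 60000 nM.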

Compound 4, half-maximal inhibitory concentration: > 10000 nM
Compound 4 was reported as a limit (the forecaster's own chance of this, stated with the estimate: 70%); the middle value is on the limit's open side.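

No step can be read from compound 1 to compound 4 or from compound 2 to compound 4, because each value is a limit and not a number: the limit of > 10000 nM in this assay, at which 4 of the 4 values shown sit. The compounds shown leave open whether hydrogen, nitro or fluoro makes any difference in this assay.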